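Methoxyphenyl amide at the end of the thioether chain

A few compounds are considered here, and "the series" means these few. Any claim that something is new, unique, unknown or untested is made for them only; others in the source may bear on it.

Measured so far in an assay on isolated protein (Mus musculus) for inhibition of IL15-IL15 receptor (Homo sapiens), read by resazurin assay, with stated times of 30 min and 2.5 days; a higher number here means a weaker inhibitor, a lower number a stronger inhibitor: compound 1 `Cn1c(Cc2nn(C)c(=O)c3ccccc23)nnc1SCCCCCCCC(=O)Nc1ccc(O)cc1O` gives 17000 nM; compound 2 `CCCOc1ccc(NC(=O)CCCCCCCSc2nnc(Cc3nn(C)c(=O)c4ccccc34)n2C)cc1` gives 1600 nM; compound 3 `CCCCCCCCCCSc1nnc(Cc2nn(C)c(=O)c3ccccc23)n1C` gives 7600 nM.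

Compound 3 stands second highest of the three numbers, between compound 1 and compound 2. Compound 4 `COc1ccc(NC(=O)CCCCCCCSc2nnc(Cc3nn(C)c(=O)c4ccccc34)n2C)cc1` differs from it by (4-methoxyphenyl)carbamoyl in place of propyl on a saturated chain carbon, seven bonds along the chain from a sulfur. Among the measured compounds shown here, two measured steps bear on this change. Going the other way round, a 2.2-fold lower number from compound 1 to compound 3 (0.35 log units; beyond the scatter) shows that swapping a plain chain end for an aryl amide with two hydroxy groups raised the number modestly, while an 11-fold lower number from compound 1 to compound 2 (1.03 log units; beyond the scatter) shows that an alkoxyphenyl in place of the dihydroxyphenyl lowered it strongly. Taken together, an alkoxyphenyl amide end should give a clearly lower number than compound 3. For the measured compounds named here, no step separates methoxy from propoxy here, so the exact size is uncertain. Compound 4 is therefore expected to give 2500 nM in this assay (range 900 nM to 7000 nM), an estimated step of a 3.0-fold lower number from compound 3 to compound 4 (0.48 log units; beyond the scatter).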

Compound 4, half-maximal inhibitory concentration: 3900 nM
Compound 4: the middle estimate sits 1.6-fold (0.19 log units) below what was measured; measured number inside the range.
By their numbers in this assay, from the lowest: compound 2; then compounds 4 and 3 (each within the scatter of the next); then compound 1.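

In this assay, the (4-methoxyphenyl)carbamoyl end and the propyl end cannot be told apart (a 1.9-fold lower number from compound 3 to compound 4 (0.29 log units; within the scatter)), so the aryl amide alone does not set compound 4 apart from the plain chain. The size of the alkoxy group does count: with hydrogen in place of ethyl on the carbon bound to the ring oxygen, the number rises (a 2.4-fold higher number from compound 2 to compound 4 (0.39 log units; beyond the scatter)). The 4-methoxyphenyl group still gives a lower number than 2,4-dihydroxyphenyl (a 4.4-fold lower number from compound 1 to compound 4 (0.64 log units; beyond the scatter)).

No supporting evidence explains these steps. Still open, on these data alone, is how a butoxy group on the ring, a carboxylic acid at the chain end or a shorter chain would compare.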